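A few compounds are considered here, and "the series" means these few. Any claim that something is new, unique, unknown or untested is made for them only; others in the source may bear on it.

Measured so far in an ADME assay on Vero cells (Chlorocebus sabaeus) for cytotoxicity, read by MTT assay, with a stated time of 72 h; a higher number here means that more compound is tolerated, a lower number that less compound is tolerated:
Compound 1 `COC(=O)c1cc(-c2cccc(NC(=O)c3ccc(/C=C/C(=O)c4cccc(Cl)c4)cc3)c2)on1` gives > 2.5 ug/mL in this assay, which is a limit of the assay rather than a number.
Compound 2 `COC(=O)c1cc(-c2cccc(NC(=O)c3ccc(/C=C/C(=O)c4ccc(F)cc4F)cc3)c2)on1` gives > 40 ug/mL in this assay, again only a limit.

For the measured compounds named here, compound 2 thus stands at a limit, as does compound 1, so the one measured step, a step that the two limits leave unreadable from compound 1 to compound 2, cannot be read for size. Compound 3 `COC(=O)c1cc(-c2cccc(NC(=O)c3ccc(/C=C/C(=O)c4ccc(C)c([N+](=O)[O-])c4)cc3)c2)on1` differs from compound 2 by 4-methyl-3-nitrophenyl in place of 2,4-difluorophenyl on a carbonyl carbon. Going by the values given here, no measured step bears readably on this change, so nothing beyond the scatter is assumed, and compound 3 is expected to show an at least 1.1-fold lower number from compound 2 to compound 3 (0.05 log units; that floor lies within the scatter). The estimate for compound 3 is 35 ug/mL, in the range 10 ug/mL to 100 ug/mL, with a fair chance that only a limit is reported again.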

Compound 3, half-maximal cytotoxic concentration: > 80 ug/mL
Compound 3 gave a limit, no number (the forecaster's own chance of this, stated with the estimate: 55%); middle value at least 2.2-fold (0.35 log units) from the limit.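

Compound 3 gives only a limit, like compound 1 and compound 2, so none of the steps among them can be read. From the compounds shown here alone, whether the group on the carbonyl carbon changes how much compound is tolerated remains open.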